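Trifluoromethylphenyl placement on the shared core

A few compounds are considered here, and "the series" means these few. Any claim that something is new, unique, unknown or untested is made for them only; others in the source may bear on it.

Compound 3 `Oc1ccc(-c2cc(-c3ccccc3C(F)(F)F)cc(-c3cccc(O)c3)n2)cc1` gives 5740 nM in a functional assay on HCT-15 cells (Homo sapiens) for inhibition; a higher number here means a weaker inhibitor, a lower number a stronger inhibitor. Among the measured compounds shown here, of the two numbers known so far this is the higher one; the nearest is compound 1 `Oc1ccc(-c2cc(-c3ccc(F)cc3)cc(-c3cccc(O)c3)n2)cc1`, which in this assay gives 5020 nM. The step of a 1.1-fold higher number from compound 1 to compound 3 (0.06 log units; within the scatter) shows that exchanging the 4-fluorophenyl for the 2-(trifluoromethyl)phenyl stayed within the scatter. Compound 2 `Oc1cccc(-c2cc(-c3ccc(C(F)(F)F)cc3)cc(-c3ccccc3O)n2)c1` in this assay reaches only a limit, > 50000 nM, and no number; this is the limit of > 50000 nM in this assay, at which 1 of the 3 values shown sits.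

Compound 4 `Oc1ccc(-c2cc(-c3ccc(C(F)(F)F)cc3)cc(-c3cccc(O)c3)n2)cc1` is not yet measured; (4-(trifluoromethyl)phenyl in place of 2-(trifluoromethyl)phenyl on an aromatic carbon). For the measured compounds named here, no measured step covers this exchange directly. Going by the values given here, the one measured step, a 1.1-fold higher number from compound 1 to compound 3 (0.06 log units; within the scatter), altered the group on the same carbon without a shift beyond the scatter. Compound 2 also carries 4-(trifluoromethyl)phenyl, though with a differently placed hydroxyphenyl, and its value is a limit only. The expectation for compound 4 is a modest move toward a higher number, a 1.6-fold higher number from compound 3 to compound 4 (0.20 log units; within the scatter), with wide uncertainty. Compound 4 is therefore estimated at 9000 nM, in the range 3000 nM to 35000 nM.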

Compound 4, half-maximal inhibitory concentration: 6440 nM
Estimate against measurement, compound 4: 1.4-fold (0.15 log units) above; low and high end bracket the measured number.
By their numbers in this assay, from the lowest: compounds 1, 3 and 4 (each within the scatter of the next). At a limit, above all of these: compound 2.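

On the carbon opposite the ring nitrogen, moving the trifluoromethyl within the phenyl group gives a 1.1-fold higher number from compound 3 to compound 4 (0.05 log units; within the scatter) in this assay and trifluoromethyl in place of fluoro gives a 1.3-fold higher number from compound 1 to compound 4 (0.11 log units; within the scatter); compounds 1, 3 and 4 are therefore not separated in this assay by either exchange. Among the compounds shown here, the one step beyond the scatter comes from the hydroxyphenyl group instead, where 4-hydroxyphenyl in place of 2-hydroxyphenyl gives an at least 7.7-fold lower number from compound 2 to compound 4 (0.89 log units; beyond the scatter). Compound 2 stands at a limit and not at a number, so that step has no exact size: the limit of > 50000 nM in this assay, at which 1 of the 4 values shown sits.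

From the compounds shown here alone, the substituents compared on this phenyl group are only fluoro and trifluoromethyl, so an amine or a carboxylic acid there remains open. Also open, going by these compounds, is whether the 3-hydroxyphenyl group tolerates a methoxy or an amino group in place of its hydroxyl.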